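The source may hold more compounds than are shown below. What is called first, only, known or untested is meant among the compounds shown, and "the series" means these compounds.

In a functional assay on MCF7 cells (Homo sapiens) for cytotoxicity, read by sulforhodamine B assay, with a stated time of 72 h (a lower number here means a stronger inhibitor, a higher number a weaker inhibitor), compound 1 (`CC(=O)O[C@@]1([C@@H]2/C(C)=C(/OC(=O)OC(C)(C)C)C(=O)C3=C(C)[C@@H](OC(=O)[C@H](O)[C@H](CC(C)C)NC(=O)OC(C)(C)C)C[C@@](O)([C@H]2OC(=O)c2ccccc2)C3(C)C)CO[C@@H]1CCOC(=O)OC(C)(C)C`) reads 51 nM and compound 2 (`CC(=O)O[C@@]1([C@@H]2/C(C)=C(/OC(=O)OCc3ccccc3)C(=O)C3=C(C)[C@@H](OC(=O)[C@H](O)[C@H](CC(C)C)NC(=O)OC(C)(C)C)C[C@@](O)([C@H]2OC(=O)c2ccccc2)C3(C)C)CO[C@@H]1CCO`) reads 53 nM on the same scale. Compound 2 therefore stands within the scatter of compound 1, and the two numbers cannot be told apart. Compound 3 (`CC(=O)O/C1=C(\C)[C@@H]([C@]2(OC(C)=O)CO[C@@H]2CCO)[C@H](OC(=O)c2ccccc2)[C@]2(O)C[C@H](OC(=O)[C@H](O)[C@H](CC(C)C)NC(=O)OC(C)(C)C)C(C)=C(C1=O)C2(C)C`) keeps the shared core of compound 2 and carries one change: methyl in place of benzyloxy on a carbonyl carbon, so that benzyloxycarbonyl becomes acetyl (methyl in place of benzyloxy on a carbonyl carbon). Within the data shown here, no measured pair shows this change, so the size of the step in this assay has no direct precedent. Starting from compound 2 at 53 nM in this series, a modest move toward a lower number is expected, though a result within the scatter would be no surprise, and the direction remains a judgement. The expected move is a 1.8-fold lower number from compound 2 to compound 3 (0.25 log units; within the scatter) as an estimate and no more. For compound 3 the estimated value is 30 nM with an expected range from 9 nM to 100 nM in the coming measurement.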

Compound 3, half-maximal inhibitory concentration: 18 nM
Estimate against measurement, compound 3: 1.7-fold (0.22 log units) above, within the range that was stated.
By their numbers in this assay, from the lowest: compound 3; then compounds 1 and 2 (each within the scatter of the next).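

In this assay, among these compounds, the step for methyl in place of benzyloxy on a carbonyl carbon, with benzyloxycarbonyl becoming acetyl, is a 2.9-fold lower number from compound 2 to compound 3 (0.47 log units; beyond the scatter), the first change that can be read at a single place. Compound 1 and compound 2 differ in more than one place, so their pair could not isolate this position; the new step shows that the number responds to the group here and that the benzyloxy group, with its six-membered aromatic ring, is not required to reach the lowest number among the three compounds. No measurement shown here bears on the reason for this step.

Going by these compounds, a single pair cannot show whether the step follows from removing the aromatic ring or from shortening the group, and how an ethyl group, a longer chain such as propyl, or an amine on the same carbonyl carbon would read in this assay remains open. It also leaves open whether the same change would give a step of similar size on a different background within the series.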